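The source may hold more compounds than are shown below. What is called first, only, known or untested is meant among the compounds shown, and "the series" means these compounds.

Compound 1 `COc1ccc(-c2cc3ccccc3nc2/C=C/C(=O)c2ccccc2)cc1` — 1410 nM in a functional assay on NCI-H1299 cells (Homo sapiens) for antiproliferative activity, read by XTT assay, with a stated time of 72 h; on this read-out lower numbers stand for stronger inhibition and higher numbers for weaker inhibition.
Compound 2 `COc1ccc(-c2cc3ccccc3nc2/C=C/C(=O)c2ccc(N)cc2)cc1` — 6510 nM in this assay.
Compound 3 `COc1ccc(-c2cc3ccccc3nc2/C=C/C(=O)c2ccco2)cc1` — 730 nM in this assay.

Compound 3 holds the lowest of the three numbers; its gap to compound 1 is within the scatter, a 1.9-fold lower number from compound 1 to compound 3 (0.29 log units; within the scatter), and only compound 2 stands clearly apart, an 8.9-fold lower number from compound 2 to compound 3 (0.95 log units; beyond the scatter). Compound 4 `COc1ccc(-c2cc3ccccc3nc2/C=C/C(=O)c2cccs2)cc1` differs from compound 3 by thiophen-2-yl in place of furan-2-yl on a carbonyl carbon. Going by the values given here, no measured step exchanges one five-membered ring for another. Among the compounds with values here, the one change at the carbonyl carbon that is known, a 1.9-fold lower number from compound 1 to compound 3 (0.29 log units; within the scatter), stayed within the scatter, whereas a 4.6-fold higher number from compound 1 to compound 2 (0.66 log units; beyond the scatter) shows that a change on that side can still move the number. On this basis no step beyond the scatter is expected in this assay: a 1.1-fold higher number from compound 3 to compound 4 (0.04 log units; within the scatter). Compound 4 is estimated at 800 nM, with a range from 300 nM to 2200 nM.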

Compound 4, half-maximal inhibitory concentration: 720 nM
Compound 4: the middle estimate sits 1.1-fold (0.05 log units) above what was measured, within the range that was stated.
By their numbers in this assay, from the lowest: compounds 4, 3 and 1 (each within the scatter of the next); then compound 2.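

In this assay, one five-membered aromatic ring on the carbonyl carbon can replace another with no step beyond the scatter, as thiophen-2-yl for furan-2-yl shows (a 1.0-fold lower number from compound 3 to compound 4 (0.01 log units; within the scatter)). Thiophen-2-yl also stays within the scatter of the phenyl group (a 2.0-fold lower number from compound 1 to compound 4 (0.29 log units; within the scatter)), while the 4-aminophenyl group remains clearly apart (a 9.0-fold lower number from compound 2 to compound 4 (0.96 log units; beyond the scatter)). Nothing available gives a reason for these results.

Open, going by these compounds, is whether thiazol-2-yl or pyridin-2-yl on the carbonyl carbon would stay within the scatter of compound 3 and compound 4. Also open, on these data alone, is whether a hydroxy group or a carboxylic acid in place of the amine would move the number as the amine does.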